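The source may hold more compounds than are shown below. What is called first, only, known or untested is meant among the compounds shown, and "the series" means these compounds.

Going by the values given here, in a functional assay on HOS-TE85 cells (Homo sapiens) for inhibition, read by CCK-8 assay, with a stated time of 72 h (a lower number here means a stronger inhibitor, a higher number a weaker inhibitor), compound 1 (`COc1ccccc1N1C(=O)CSC1c1cc(F)cc(C(=O)NCCCCc2ccccc2)c1`) gives 40.9 nM as the higher, weaker of the two numbers so far, and compound 2 (`COc1ccccc1N1C(=O)CSC1c1cc(C)cc(C(=O)NCCCCc2ccccc2)c1`) gives 16.2 nM as the lower. Compound 3 (`COc1ccccc1N1C(=O)CSC1c1cc(F)cc(C(=O)O)c1`) differs from compound 1 (hydroxy in place of (4-phenylbutyl)amino on a carbonyl carbon) by having hydroxy in place of (4-phenylbutyl)amino on a carbonyl carbon. Among the compounds with values here, the only measured step (a 2.5-fold lower number from compound 1 to compound 2 (0.40 log units; beyond the scatter)) is modest and is a different change, methyl in place of fluoro on an aromatic carbon, so no measurement covers this one directly. A large rise in the number is expected (a 370-fold higher number from compound 1 to compound 3 (2.56 log units; beyond the scatter)) since so much of the molecule leaves. For compound 3 the estimated value is 15000 nM (expected range 2000 nM to 80000 nM).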

Compound 3, half-maximal inhibitory concentration: > 1000 nM
Compound 3 was reported as a limit; the forecaster's own chance of this, stated with the estimate: 45%; the middle value does not contradict the limit.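

Putting hydroxy in place of (4-phenylbutyl)amino on the carbonyl carbon gives an at least 24-fold higher number from compound 1 to compound 3 (1.38 log units; beyond the scatter) and so outweighs the modest methyl-for-fluoro step seen earlier. Compound 3 is reported only as a limit (> 1000 nM). The group on this carbonyl carbon therefore matters greatly for activity in these cells, but the full size of the rise cannot be read: the limit of > 1000 nM in this assay, at which 1 of the 3 values shown sits.

Still open, from the compounds shown here alone, is which part of the departing group counts: the nitrogen, the chain or its phenyl ring. A shorter chain ending in phenyl, or a simple methylamine amide, would help separate these.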